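Swapping Cyano for Nitro on the Shared Core

This account rests on a few compounds, and the source may have more. Where it says the series, first, only, none or still open, it means among the compounds named here.

Among the compounds with values here, only two compounds have numbers so far. In a functional assay (aorta) with Rattus norvegicus as the target (a lower number here means that less compound is needed, a higher number that more compound is needed for the effect), compound 1 (`O=C1CCCCN1[C@@H]1c2cc([N+](=O)[O-])ccc2OC(CF)(CF)[C@H]1O`) gives 2.75 nM while compound 2 (`N#Cc1ccc2c(c1)[C@@H](n1ccccc1=O)[C@H](O)C(CF)(CF)O2`) gives 148 nM as the higher of the two numbers, a gap well beyond the scatter. Compound 2 thus stands at the top of this short scale. The next structure, compound 3 (`O=c1ccccn1[C@@H]1c2cc([N+](=O)[O-])ccc2OC(CF)(CF)[C@H]1O`), has nitro in place of cyano on an aromatic carbon, on a six-membered aromatic ring of carbon only, part of a fused or bridged system of two rings. Within the data shown here, no step between measured compounds isolates this change, and the data hold no direct measure of it. Compound 1 also carries nitro and gives 2.75 nM in this comparison, which makes it a loose guide. A move to a lower number in this assay is expected, beyond the scatter but short of the full gap, and the estimated size is a 7.4-fold lower number from compound 2 to compound 3 (0.87 log units; beyond the scatter) for this change. For compound 3 the estimated value is 20 nM within an expected range of 4 nM to 100 nM in this assay.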

Compound 3, half-maximal effective concentration: 28.8 nM
Compound 3: middle estimate off by 1.4-fold (0.16 log units), on the low side, and the stated range covers the measured number.
By their numbers in this assay, from the lowest: compound 1; then compound 3; then compound 2.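

Within the data shown here, the measurement gives the first reading of the aromatic carbon on its own: with everything else on the shared core held the same, nitro in place of cyano gives a 5.1-fold lower number from compound 2 to compound 3 (0.71 log units; beyond the scatter) in this assay, a modest step. It also separates a second place, the saturated ring carbon, where the group with a six-membered aromatic ring with one hetero atom, in place of the group with a six-membered non-aromatic ring with one hetero atom, gives a 10-fold higher number from compound 1 to compound 3 (1.02 log units; beyond the scatter), a large step. Both places therefore move the number beyond the scatter, though no supporting data are available to explain either step.

Each change has been read only once, on a single background, so the compounds shown leave open whether the nitro-for-cyano step would keep its size with the non-aromatic ring on the saturated ring carbon, and whether the ring step would keep its size with cyano on the aromatic carbon. They also leave open how a chlorine atom or an amine on that aromatic carbon would compare with nitro and cyano in this assay.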